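The source may hold more compounds than are shown below. What is called first, only, known or untested is meant among the compounds shown, and "the series" means these compounds.

Measured so far:
- compound 1 `COc1ccc(-c2nnc(-c3nn(C)c4ccccc34)o2)cc1`: > 100000 nM in an ADME assay on L02 cells (Homo sapiens) for cytotoxicity, read by MTT assay, with a stated time of 72 h; a higher number here means a weaker inhibitor, a lower number a stronger inhibitor
- compound 2 `Cn1nc(-c2nnc(-c3ccccc3Br)o2)c2ccccc21`: 89000 nM in this assay

Compound 1 stands at the limit of > 100000 nM in this assay, at which 1 of the 2 values shown sits; its value in this assay is a limit of the assay, not a number, so only a floor is known for it. Compound 2, which carries a bromo group instead of the methoxy, gives a measured number in this assay, and that number sits close to where the limit of compound 1 is placed. Going by the values given here, no step between two measured compounds is available here, so there is nothing to show how a change on the phenyl ring of the shared core moves the read-out.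

Compound 3 `Cn1nc(-c2nnc(-c3ccc(Br)cc3)o2)c2ccccc21` is not yet measured. It differs from compound 1 by bromo in place of methoxy on an aromatic carbon. With compound 1 at a limit and compound 2 near that limit, the step of an at least 1.1-fold lower number from compound 1 to compound 3 (0.04 log units; that floor lies within the scatter) is expected to be none beyond the scatter. For compound 3 in this assay an estimate of 90000 nM is given, with a range of 40000 nM to 200000 nM, and a real chance that this assay reports only a limit for compound 3 rather than a number.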

Compound 3, half-maximal inhibitory concentration: > 100000 nM
Compound 3: no number, only a limit; the forecaster's own chance of this, stated with the estimate: 50%; at least 1.1-fold (0.04 log units) between middle value and limit.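

In this assay compound 3 gives > 100000 nM, which is a limit of the assay and not a number. With 4-bromophenyl in place of 2-bromophenyl, the series shows an at least 1.1-fold higher number from compound 2 to compound 3 (0.05 log units; that floor lies within the scatter), so moving the bromo on this ring produces no change that can be told from the scatter, though only a floor is known for this step. The step for bromo in place of methoxy on an aromatic carbon cannot be read, as both of its ends are limits, and the read-outs of the series now gather at a single ceiling: the limit of > 100000 nM in this assay, at which 2 of the 3 values shown sit.

Where compound 1 and compound 3 truly lie past that limit remains open, and with it any ranking of methoxy against bromo at this place. Also open, from the compounds shown here alone, is whether an amine or a carboxylic acid on this aromatic carbon would give this assay a number clearly lower than that of compound 2, at 89000 nM. Such a group might instead leave the read-out at the same ceiling.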